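The compounds below may be only part of what the source reports. "The series", "measured", "known", "first", "only" and "open" are said of these compounds alone.

Working notes on the series

Three compounds are measured in an ADME assay on microsomes from liver (Homo sapiens), read by LC-MS, using NADPH, with a stated time of 30 min, tested at 1 uM (on this read-out higher numbers stand for a more stable compound and lower numbers for a less stable compound), all sharing a cyanopyrimidinylamino group joined through a methyl-bearing stereocentre to a bicyclic core. Compound 2 `C[C@H](Nc1nc(N)ncc1C#N)c1cc2ccc(F)cn2c(=O)c1-c1ccccc1` gives 90% in this assay. Compound 1 `C[C@H](Nc1nc(N)nc(N)c1C#N)c1cc2ccc(F)cn2c(=O)c1-c1ccccc1` carries one more amino group on the pyrimidine ring and gives 87%. The change between them is amino in place of hydrogen on an aromatic carbon, and the step it made is a number 3 percentage points lower from compound 2 to compound 1 (within the scatter). Compound 3 `C[C@H](Nc1ncnc(N)c1C#N)c1c(C2CC2)c(=O)n2cc(F)ccc2c1-c1ccc(F)cc1` has a different core, with a cyclopropyl group and a fluorophenyl group in place of the phenyl group; the difference between the two cores is not broken down here. In this assay compound 3 gives 93%; the two values of compound 3 and compound 2 and the two of compound 3 and compound 1 lie within the scatter of each other.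

Compound 4 `C[C@H](Nc1nc(N)nc(N)c1C#N)c1c(C2CC2)c(=O)n2cc(F)ccc2c1-c1ccc(F)cc1` is not yet measured. It differs from compound 3 by amino in place of hydrogen on an aromatic carbon. This is the same kind of change as from compound 2 to compound 1, but not the same: in compound 1 the entering amino group sits next to the ring nitrogen, ortho to a cyano group and opposite the ring nitrogen, whereas in compound 4 it sits between two ring nitrogen atoms and para to a cyano group. For compound 4 in this assay the expected step is a number 2 percentage points lower from compound 3 to compound 4 (within the scatter), which rests on the earlier step being within the scatter, because a number 3 percentage points lower from compound 2 to compound 1 (within the scatter) gives no sign of a shift. The estimate for compound 4 in this assay is 91%, expected to fall between 82% and 98%.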

Compound 4, percent of the compound remaining: 86%
Compound 4: the middle estimate sits 5 percentage points above what was measured; measured number inside the range.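

The amino group entering between two ring nitrogen atoms and para to a cyano group gives, in this assay, a number 7 percentage points lower from compound 3 to compound 4 (within the scatter) on the cyclopropyl-bearing core. Set beside the earlier step, the change reads alike on the two cores, with no difference that stands clear of the scatter: the same change on two cores in this assay, a number 3 percentage points lower (within the scatter) from compound 2 to compound 1 and a number 7 percentage points lower (within the scatter) from compound 3 to compound 4, 4 percentage points apart, within the scatter of two such steps. Among the compounds shown here, this shows only that neither pair gives a step beyond the scatter in this assay, and it does not show that the two steps are equal, that the change has no effect on stability, or that the result would hold on any further core; the entering amino group also takes a different place on the pyrimidine ring in each pair, so core and ring place cannot be separated here.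

The compounds shown leave open how a methylamino or dimethylamino group, or a methoxy group, would read in this assay at the ring carbon that takes the amino group here. They also leave open whether the step would look the same on either core with a carboxamide in place of the cyano group.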